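The source may report more compounds than this note shows. Statements on the series, on what has been measured and on what is new or still open speak of the compounds shown alone.

Compound 1 `Cc1nc(N)c2c(-c3ccccc3)cn([C@@H]3O[C@H](CO)[C@@H](O)[C@H]3O)c2n1` gives > 20000 nM in a functional assay on HCT-116 cells (Homo sapiens), read by MTT assay, with a stated time of 72 h (a higher number here means a weaker inhibitor, a lower number a stronger inhibitor), which is a limit of the assay rather than a measured number.
Compound 2 `C#Cc1cn([C@@H]2O[C@H](CO)[C@@H](O)[C@H]2O)c2nc(C)nc(N)c12` gives > 20000 nM in this assay, again a limit.
Compound 3 `COc1ncnc2c1c(-c1ccccc1)cn2[C@@H]1O[C@H](CO)[C@@H](O)[C@H]1O` gives > 20000 nM in this assay, also a limit.

All three measured compounds carry the same sugar on a two-ring core, and all three sit at the limit of > 20000 nM in this assay, at which 3 of the 3 values shown sit. Between compound 1 and compound 2 the only structural change is ethynyl in place of phenyl on an aromatic carbon. The step that the two limits leave unreadable from compound 1 to compound 2 therefore cannot be read, since both ends are limits and no number lies behind either. Compound 3 has a different core from compound 1; the difference between the two cores is not broken down here.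

Compound 4 `C#Cc1cn([C@@H]2O[C@H](CO)[C@@H](O)[C@H]2O)c2ncnc(OC)c12` has not yet been measured. It differs from compound 3 by ethynyl in place of phenyl on an aromatic carbon, which is the same change that separates compound 1 from compound 2, made on the same place. That earlier change produced no readable step because compound 1 and compound 2 both sit at the limit of > 20000 nM in this assay, at which 3 of the 3 values shown sit. Compound 3 also sits there, so there is no measured movement anywhere to build on. The expectation for compound 4 is that the same change on the core of compound 3 again leaves the value out of reach, so the step that the limit leaves unreadable from compound 3 to compound 4 is expected to be essentially nothing readable. The estimate for compound 4 is 25000 nM, most likely reported as a limit once more.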

Compound 4, half-maximal inhibitory concentration: 5140 nM
Beside the measured number, compound 4's estimate is 4.9-fold (0.69 log units) above it; the whole stated range lies above it.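

In this assay, putting ethynyl in place of phenyl on an aromatic carbon gives an at least 3.8-fold lower number from compound 3 to compound 4 (0.59 log units; beyond the scatter), so on the core of compound 3 this change produces a clear, readable move towards a stronger inhibitor, and its true size could be larger still. The same change on the core of compound 1 cannot be read, since the two ends of the step from compound 1 to compound 2 are both limits, so the result does not show that the change fails on that core, nor that it carries over to it. The one readable step therefore stands alone, and the series offers no second number to set against it, with most of the values still at the ceiling: the limit of > 20000 nM in this assay, at which 3 of the 4 values shown sit.

Open, on these data alone, is whether the effect belongs to ethynyl itself or would also appear with another group on the same aromatic carbon, such as a nitrile, a chlorine atom or a methyl group. Also open, as far as these compounds go, is whether a longer chain ending in a triple bond, such as propynyl, would move the value further, and whether an amine or a methylthio group in place of the methoxy group of compound 4 would keep the activity.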